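The compounds below may be only part of what the source reports. "The series", "measured", "known", "first", "only" and "open" are said of these compounds alone.

Compound 1, with the structure `CC(C)(C)c1ccc(C(=O)NNc2c(Br)cccc2Br)cc1`, is one of three compounds tested in a toxicity assay on MDCK cells (Canis lupus familiaris) for cytotoxicity, read by CCK-8 assay, with a stated time of 48 h; a lower number here means that less compound is tolerated, a higher number that more compound is tolerated. In this assay compound 1 gives > 100000 nM, a limit of the assay rather than a measured number. Compound 2, `COc1cccc(C(=O)NNc2c(Br)cccc2Br)c1`, gives > 100000 nM in this assay, again a limit. Among the compounds with values here, compound 3, `Cc1cccc(C)c1NNC(=O)c1ccc(C(C)(C)C)cc1`, gives > 100000 nM in this assay, also a limit. the limit of > 100000 nM in this assay, at which 3 of the 3 values shown sit, is all that the measured compounds show, so no step between them has been measured. Compound 4, `O=C(NNc1c(Br)cccc1Br)c1ccc(B(O)O)cc1`, has not yet been tested in this assay; compared with compound 1 the change is a group of 3 heavy atoms (1 boron, 2 oxygen; no ring) in place of a group of 4 heavy atoms (4 carbon; no ring), on an aromatic carbon. The step of a number no higher from compound 1 to compound 4 (the limit leaves the size open) is expected to be none beyond the scatter. Compound 4 is therefore expected to give about 100000 nM in this assay, with a range of 40000 nM to 300000 nM.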

Compound 4, half-maximal cytotoxic concentration: > 100000 nM
Compound 4: a limit, no number; the forecaster's own chance of this, stated with the estimate: 85%; the middle value sits exactly at the limit.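

No step from compound 1 to compound 4 can be read in this assay, since both values are limits: the limit of > 100000 nM in this assay, at which 4 of the 4 values shown sit.

The compounds shown leave open the concentration at which any of them harms these cells, and whether swapping the tert-butyl group changes that concentration at all.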